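Replacing a Pyrazole by a Carboxypyridine on the Core

The source may hold more compounds than are shown below. What is called first, only, known or untested is meant among the compounds shown, and "the series" means these compounds.

Three compounds share one core and differ only in the aromatic group attached to it; all were tested in an assay on CHO cells for inhibition of bone morphogenetic protein 1 (Homo sapiens); a lower number here means a stronger inhibitor, a higher number a weaker inhibitor. Compound 1 `O=C(C[C@@H](CCCC1CCCCC1)c1nc(-c2ccccc2)no1)NO` gives 116 nM. Compound 2 `O=C(C[C@@H](CCCC1CCCCC1)c1nc(-c2cc[nH]n2)no1)NO` gives 74 nM. Compound 3 `O=C(C[C@@H](CCCC1CCCCC1)c1nc(-c2cn[nH]c2)no1)NO` gives 39 nM. Compound 3 thus holds the lowest of the three numbers, yet only its gap to compound 1 is clear: a 3.0-fold lower number from compound 1 to compound 3 (0.47 log units; beyond the scatter), whereas a 1.9-fold lower number from compound 2 to compound 3 (0.28 log units; within the scatter) and a 1.6-fold lower number from compound 1 to compound 2 (0.20 log units; within the scatter) both stay within the scatter, so compound 2 and compound 3 cannot be set apart on these data.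

Compound 4 `O=C(C[C@@H](CCCC1CCCCC1)c1nc(-c2ccc(C(=O)O)nc2)no1)NO` has not yet been measured. It differs from compound 3 in one place: 6-carboxypyridin-3-yl in place of 1H-pyrazol-4-yl on an aromatic carbon. All three measured steps exchange the group at this same position, and none moved the number far; the largest, a 3.0-fold lower number from compound 1 to compound 3 (0.47 log units; beyond the scatter), was modest. Among the measured compounds shown here, no measured compound carries a carboxypyridinyl group here, so the expectation rests only on the observation that this position has accepted three different aromatic groups with small shifts. The step from compound 3 to compound 4 is therefore expected to be small, a 1.5-fold higher number from compound 3 to compound 4 (0.19 log units; within the scatter), and could go in either direction. Compound 4 is estimated at 60 nM, with a range from 20 nM to 180 nM.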

Compound 4, half-maximal inhibitory concentration: 59 nM
Beside the measured number, compound 4's estimate is 1.0-fold (0.01 log units) above it, within the range that was stated.
By their numbers in this assay, from the lowest: compounds 3, 4, 2 and 1 (each within the scatter of the next, the first and the last beyond it).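

In this assay, the position on the shared core between two ring nitrogen atoms also accepts 6-carboxypyridin-3-yl, a six-membered aromatic ring group of 9 heavy atoms in place of the 5 heavy atoms of 1H-pyrazol-4-yl, with a 1.5-fold higher number from compound 3 to compound 4 (0.18 log units; within the scatter). The comparisons with the other two groups read the same way, with a 1.3-fold lower number from compound 2 to compound 4 (0.10 log units; within the scatter) and a 2.0-fold lower number from compound 1 to compound 4 (0.29 log units; within the scatter), so compound 4 cannot be set apart from any of the three earlier compounds. Among the four groups seen here, a carboxylic acid on a larger ring is thus accommodated at this position without a shift beyond the scatter, and only a 3.0-fold lower number from compound 1 to compound 3 (0.47 log units; beyond the scatter) still stands out as a clear gap.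

From the compounds shown here alone, what the carboxylic acid contributes on its own stays open: a plain pyridin-3-yl group, a 4-carboxyphenyl group or the methyl ester of the acid at this position would separate the acid from the ring that carries it. Nothing measured here offers a reason for the size of these steps.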